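Methyl to Methoxy on a Second Core

The source may report more compounds than this note shows. Statements on the series, on what has been measured and on what is new or still open speak of the compounds shown alone.

Measured so far:
Compound 1 `COc1ccc(OC(C)(C)C2OCC(C/C=C\CCC(=O)O)C(c3cccnc3)O2)cc1` gives 302 nM in a functional assay for inhibition, with Homo sapiens as the target; on this read-out higher numbers stand for weaker binding and lower numbers for tighter binding.
Compound 2 `Cc1ccc(OC(C)(C)C2OCC(C/C=C\CCC(=O)O)C(c3cccnc3)O2)cc1` gives 631 nM in this assay.
Compound 3 `Cc1ccc(SC(C)(C)C2OCC(C/C=C\CCC(=O)O)C(c3cccnc3)O2)c([N+](=O)[O-])c1` gives 158 nM in this assay.

Compound 4 `COc1ccc(SC(C)(C)C2OCC(C/C=C\CCC(=O)O)C(c3cccnc3)O2)c([N+](=O)[O-])c1` has not yet been measured. It differs from compound 3 by methoxy in place of methyl on an aromatic carbon. The same change has been made once before, between compounds 2 and 1, as methoxy in place of methyl on an aromatic carbon, and it gave a 2.1-fold lower number from compound 2 to compound 1 (0.32 log units; beyond the scatter). The two cores are not identical: compound 3 differs from compound 2 by a group of 11 heavy atoms (7 carbon, 1 nitrogen, 2 oxygen, 1 sulfur; one six-membered aromatic ring of carbon only) in place of a group of 8 heavy atoms (7 carbon, 1 oxygen; one six-membered aromatic ring of carbon only), on a saturated chain carbon bound to two saturated chain carbons and a saturated ring carbon, a core change that gave a 4.0-fold lower number from compound 2 to compound 3 (0.60 log units; beyond the scatter). The surroundings of the change also differ: in compound 4 the aromatic carbon is meta to a nitro group as well as para to a large group, so this is the same kind of change, not the same change. Because a 2.1-fold lower number from compound 2 to compound 1 (0.32 log units; beyond the scatter) is modest, a step of similar size is expected here, a 1.9-fold lower number from compound 3 to compound 4 (0.27 log units; within the scatter). Compound 4 is therefore estimated at 85 nM, most likely between 35 nM and 200 nM.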

Compound 4, dissociation constant: 158 nM
For compound 4 the middle estimate is 1.9-fold (0.27 log units) below the measured one; the range from low to high includes it.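

In this assay, methoxy in place of methyl on the second core gives no change at the digits printed from compound 3 to compound 4 (within the scatter). Set beside the earlier step on the first core, the two results differ by no more than repeated measurements could: the same change on two cores in this assay, a 2.1-fold lower number (0.32 log units; beyond the scatter) from compound 2 to compound 1 and no change at the digits printed (within the scatter) from compound 3 to compound 4, 2.1-fold (0.32 log units) apart, within the scatter of two such steps. The two pairs are therefore compatible with the change carrying over from one core to the other, but two pairs cannot show that the step has one fixed size in this series, or that methoxy lowers the number on the core of compound 3.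

On these data alone, it remains open whether an amine or a longer chain such as ethoxy on this aromatic carbon would behave alike on both cores. Also open is how the sulfur and the nitro group each count, as every compound shown carries both or neither.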